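The source may report more compounds than this note shows. Statements on the series, on what has been measured and on what is new or still open speak of the compounds shown alone.

In a functional assay on MOLT-4 cells (Homo sapiens) for antiproliferative activity (a lower number here means a stronger inhibitor, a higher number a weaker inhibitor), compound 1 (`COc1ccc(-c2cc(N)c(C(=O)c3cc(OC)c(OC)c(OC)c3)s2)cc1OC`) gives 20 nM and compound 2 (`COc1cc(C(=O)c2sc(-c3ccc(Cl)cc3)cc2N)cc(OC)c1OC`) gives 77 nM, while compound 3 (`COc1cc(C(=O)c2sc(-c3ccc(I)cc3)cc2N)cc(OC)c1OC`) gives 190 nM as the highest number of the three, which makes it the weakest inhibitor among them. Compound 4 (`COc1cc(C(=O)c2sc(-c3ccccc3)cc2N)cc(OC)c1OC`) has hydrogen in place of iodo on an aromatic carbon. For the measured compounds named here, no measured step removes the group from this position outright. The nearest guide is the modest swap of chloro for iodo (a 2.5-fold higher number from compound 2 to compound 3 (0.39 log units; beyond the scatter)). Replacing 3,4-dimethoxyphenyl also gave modest steps (a 3.9-fold higher number from compound 1 to compound 2 (0.59 log units; beyond the scatter) and a 9.5-fold higher number from compound 1 to compound 3 (0.98 log units; beyond the scatter)), but neither involves a plain phenyl. Going by these compounds, no step beyond the scatter is therefore expected in this assay and the direction stays open. The estimated step is small (a 1.2-fold higher number from compound 3 to compound 4 (0.06 log units; within the scatter)). Compound 4 is estimated at 220 nM with 70 nM to 700 nM as its expected range.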

Compound 4, half-maximal inhibitory concentration: 5.3 nM
Compound 4: the middle estimate sits 42-fold (1.62 log units) above what was measured; the measured number lies below the stated range.
By their numbers in this assay, from the lowest: compound 4; then compound 1; then compound 2; then compound 3.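

In this assay, removing the halogen matters far more than exchanging one halogen for another: hydrogen in place of iodo gives a 36-fold lower number from compound 3 to compound 4 (1.55 log units; beyond the scatter), and hydrogen in place of chloro gives a 15-fold lower number from compound 2 to compound 4 (1.16 log units; beyond the scatter). Plain phenyl also outperforms 3,4-dimethoxyphenyl, with a 3.8-fold lower number from compound 1 to compound 4 (0.58 log units; beyond the scatter), making compound 4 the strongest inhibitor of the four. Nothing available explains why the unsubstituted ring does best.

Going by these compounds, it remains open whether every group on this ring carbon raises the number, or whether one as small as fluoro or methyl would keep it close to that of compound 4.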